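A Methoxy Swap on a Pyridinone Scaffold

This account rests on a few compounds, and the source may have more. Where it says the series, first, only, none or still open, it means among the compounds named here.

Compound 1 `O=C1CCCC2=C1C(c1ccc(Cl)cc1)C=C(c1ccccc1)N2` gives 8.21% in an assay on isolated protein for inhibition of glucose-6-phosphatase catalytic subunit 1 (Homo sapiens), read by inositol phosphate accumulation, with a stated time of 30 min, tested at 100 uM (on this read-out higher numbers stand for more inhibition at the one concentration tested (going by the name of the read-out) and lower numbers for less inhibition), a small response at the single concentration tested. Its close relative compound 2 `O=C1CCCC2=C1C(c1ccccc1)C=C(c1ccccc1)N2` is reported in this assay as "not active" (no number reported), so no number is available for it, and nothing can be said about how far it lies from compound 1. Compound 3 `COc1ccc(C2C=C(c3ccccc3)NC3=C2C(=O)CCC3)cc1` arises from compound 2 through one change, (methoxy in place of hydrogen on an aromatic carbon), on an aromatic carbon of a six-membered aromatic ring of carbon only. Going by the values given here, no measured step covers this change; little movement beyond the scatter is expected in this assay. Compound 3 is therefore estimated at 5%, within 0% to 20%.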

Compound 3, a percentage reported as inhibition, at one concentration (the size of the read-out at that concentration, not a potency): 17.3%
Beside the measured number, compound 3's estimate is 12.3 percentage points below it; the measured number falls inside the stated range.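

In this assay, putting methoxy in place of chloro gives a number 9.1 percentage points higher from compound 1 to compound 3 (within the scatter), so these two groups cannot be told apart at this position on the ring. The step from hydrogen to methoxy cannot be read, since compound 2 has no number, although compound 3 has a measured response and compound 2 is reported as not active. No available evidence explains these readings. From the compounds shown here alone, it remains open how an amine or a carboxylic acid would read at this position, and whether any group there could give a much larger response.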